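Amino for Methylsulfonyl at the Edge of Growth Inhibition

The source may hold more compounds than are shown below. What is called first, only, known or untested is meant among the compounds shown, and "the series" means these compounds.

Compound 1 `Oc1cc(-c2ccccc2)nn1-c1ccc(F)cn1` gives 28900 nM in an ADME assay on WI-38 cells (Homo sapiens) for inhibition, read by CellTiter-Glo, with a stated time of 4 days; a lower number here means a stronger inhibitor of growth, a higher number a weaker inhibitor of growth. Compound 2 `CS(=O)(=O)c1ccc(-n2nc(-c3ccccc3)cc2O)nc1` sits at a limit in this assay, namely > 30000 nM. The step of an at least 1.0-fold higher number from compound 1 to compound 2 (0.01 log units; that floor lies within the scatter) is the only measured one, and it runs into the limit (the limit of > 30000 nM in this assay, at which 1 of the 2 values shown sits). Compound 3 `Nc1ccc(-n2nc(-c3ccccc3)cc2O)nc1` differs from compound 2 by amino in place of methylsulfonyl on an aromatic carbon. Nothing measured touches an amino group, so compound 2 only fixes where compound 3 starts, and the expected step of a number no higher from compound 2 to compound 3 (the limit leaves the size open) stays within the scatter. Compound 3 is therefore estimated at 30000 nM, with a range from 12000 nM to 75000 nM, and it may well return only a limit again.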

Compound 3, concentration for 50% growth inhibition: > 30000 nM
Compound 3 was reported as a limit; the forecaster's own chance of this, stated with the estimate: 55%; the middle value lies on the limit itself.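

In this assay compound 3 gives > 30000 nM, which is a limit of the assay and not a number. Against fluoro, the one readable step is an at least 1.0-fold higher number from compound 1 to compound 3 (0.01 log units; that floor lies within the scatter), so the values do not separate amino from fluoro at this position. The step between compound 2 and compound 3 cannot be read, because both values are limits: the limit of > 30000 nM in this assay, at which 2 of the 3 values shown sit.

From the compounds shown here alone, whether a carboxylic acid or a methoxy group on this aromatic carbon would give a value clear of the limit remains open. So does the true value of compound 2 and of compound 3.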